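Swapping methoxy for iodo on a coumarin-linked isatin core

The compounds below may be only part of what the source reports. "The series", "measured", "known", "first", "only" and "open" are said of these compounds alone.

Of the compounds shown here, three sharing one core have been tested in a functional assay on COLO 205 cells (Homo sapiens) for inhibition, read by sulforhodamine B assay, with a stated time of 48 h, tested at 50 uM; on this read-out higher numbers stand for more inhibition of growth at the one concentration tested and lower numbers for less inhibition of growth. Compound 1 `COc1ccc2c(c1)C(=O)C(=O)N2CCCCCn1cc(COc2cc(=O)oc3ccccc23)nn1` carries a methoxy group on its fused aromatic ring and a five-carbon linker; in this assay compound 1 gives 19%, the lowest of the three numbers. Compound 3 `COc1ccc2c(c1)C(=O)C(=O)N2CCCCn1cc(COc2cc(=O)oc3ccccc23)nn1` keeps the methoxy group but has a four-carbon linker, and compound 3 gives 41%, beyond the scatter above compound 1. Compound 2 `O=C1C(=O)N(CCCn2cc(COc3cc(=O)oc4ccccc34)nn2)c2ccc(I)cc21` carries an iodo group and a three-carbon linker, and compound 2 gives 56%, the furthest from compound 1 and also beyond the scatter.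

Compound 4 `O=C1C(=O)N(CCCCCn2cc(COc3cc(=O)oc4ccccc34)nn2)c2ccc(I)cc21` has not yet been measured. It differs from compound 1 in one place: iodo in place of methoxy on an aromatic carbon. Within the data shown here, no measured pair shows this change on its own, so its size can only be guessed from the compounds above. Because compound 2 with its iodo group reaches 56%, an increase in growth inhibition of about a number 16 percentage points higher from compound 1 to compound 4 (beyond the scatter) is expected, with compound 4 estimated at 35% within a range of 15% to 58%.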

Compound 4, percent growth inhibition at one concentration: 30%
Estimate against measurement, compound 4: 5 percentage points above, and the stated range covers the measured number.
By their numbers in this assay, from the lowest: compound 1; then compound 4; then compound 3; then compound 2.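

In this assay, among these compounds, putting iodo in place of methoxy on this aromatic carbon, with the five-carbon linker and the rest of the molecule unchanged, gives a number 11 percentage points higher from compound 1 to compound 4 (beyond the scatter) and so isolates this change for the first time. The iodo group alone does not bring the highest number seen, as the two iodo compounds differ only in linker length, with compound 2 (shorter linker) at (56%) and compound 4 at (30%). No measurement available here explains why this swap raises growth inhibition.

The compounds shown leave open whether the same swap gives a similar step on a shorter linker. They also leave open how a smaller halogen such as fluoro or chloro, or an amine or a carboxylic acid, would read at this aromatic carbon.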